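Swapping a Fluorophenyl Ring for a Furan Ring

A few compounds are considered here, and "the series" means these few. Any claim that something is new, unique, unknown or untested is made for them only; others in the source may bear on it.

Compound 1 `CC1=CC[C@H](C(C)(C)NC(=S)N/N=C/c2ccccc2)CC1` gives 9900 nM in a functional assay on 786-0 cells (Homo sapiens) for inhibition, read by sulforhodamine B assay, with a stated time of 48 h; on this read-out higher numbers stand for weaker inhibition of growth and lower numbers for stronger inhibition of growth.
Compound 2 `CC1=CC[C@H](C(C)(C)NC(=S)N/N=C/c2ccc(O)cc2)CC1` gives > 100000 nM in this assay, a limit of the assay.
Compound 3 `CC1=CC[C@H](C(C)(C)NC(=S)N/N=C/c2ccc(F)cc2)CC1` gives > 100000 nM in this assay, a limit of the assay.

Compound 3 stands at the limit of this assay, so for it only a limit and no number is known, and the same holds for one further value, as the limit of > 100000 nM in this assay, at which 2 of the 3 values shown sit, shows. Among the measured steps, an at least 10-fold higher number from compound 1 to compound 2 (1.00 log units; beyond the scatter) and an at least 10-fold higher number from compound 1 to compound 3 (1.00 log units; beyond the scatter) both weakened growth inhibition; in each a hydrogen on the phenyl ring was exchanged for a substituent. The step that the two limits leave unreadable from compound 2 to compound 3 cannot be sized.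

Compound 4 `CC1=CC[C@H](C(C)(C)NC(=S)N/N=C/c2ccco2)CC1` differs from compound 3 by furan-2-yl in place of 4-fluorophenyl on a carbon with a double bond to nitrogen. Going by the values given here, no measured step exchanges the whole ring, so the two steps that bear on it give only indirect guidance: the substituted phenyl rings sit at the limit, while the unsubstituted ring of compound 1 does not. Furan-2-yl carries no such substituent, so compound 4 is expected to stand somewhere between compound 1 and the limit, with an at least 2.5-fold lower number from compound 3 to compound 4 (0.39 log units; beyond the scatter). The estimate for compound 4 in this assay is 40000 nM, with a range from 8000 nM to 150000 nM.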

Compound 4, concentration for 50% growth inhibition: 11700 nM
The estimate for compound 4 lay 3.4-fold (0.53 log units) above the measured number, within the range that was stated.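

At this place, on a carbon with a double bond to nitrogen, the ring can be exchanged without a readable change in this assay: furan-2-yl in compound 4 and phenyl in compound 1 give values within the usual scatter of each other, with a 1.2-fold higher number from compound 1 to compound 4 (0.07 log units; within the scatter). Against the substituted rings, the same furan-2-yl gives much stronger inhibition of growth, with an at least 8.5-fold lower number from compound 3 to compound 4 (0.93 log units; beyond the scatter) and an at least 8.5-fold lower number from compound 2 to compound 4 (0.93 log units; beyond the scatter). Among these four compounds, then, a five-membered ring containing oxygen serves as well as an unsubstituted six-membered ring of carbon only, and the two compounds that give a number rather than a limit both carry a ring without a substituent.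

How far compound 2 and compound 3 truly lie from compound 4 remains unknown, and the step between compound 2 and compound 3 cannot be read, because their values are limits of the assay: the limit of > 100000 nM in this assay, at which 2 of the 4 values shown sit.

The compounds shown also leave open whether a methyl group on the furan ring, a thiophene ring in its place, or an amine on the phenyl ring would keep the number measurable.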